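The compounds below may be only part of what the source reports. "The series", "measured", "known", "first", "only" and "open" are said of these compounds alone.

Measured so far:
compound 1, `Cc1ccc(CN2CCC(C(=O)Nc3ccc(CNc4nc(N(C)C)nc5cc(C)ccc45)cc3)CC2)cc1` — > 4150 nM
compound 2, `Cc1ccc2c(NCc3ccc(NC(=O)C4CCN(Cc5ccccc5)CC4)cc3)nc(N3CCNC(CCO)C3)nc2c1` — > 8420 nM

In a functional assay on SV5A8 cells (Homo sapiens) for cytotoxicity (a higher number here means a weaker inhibitor, a lower number a stronger inhibitor), compound 1 returns only a limit, > 4150 nM, so its standing is not fixed by a number. Compound 2 likewise returns only a limit in this assay, > 8420 nM. Compound 1 sits at the limit of > 4150 nM in this assay, at which 1 of the 2 values shown sits. Compound 2 sits at the limit of > 8420 nM in this assay, at which 1 of the 2 values shown sits. Among the compounds with values here, with both values at a limit, no step between measured compounds can be sized, and nothing shows where a number would fall below either limit.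

Compound 3, `Cc1ccc2c(NCc3ccc(NC(=O)C4CCN(C5CCCCC5)CC4)cc3)nc(N(C)C)nc2c1`, is not yet measured; it differs from compound 1 by cyclohexyl in place of 4-methylbenzyl on an amine nitrogen in a ring. Within the data shown here, since the only comparison available, compound 1 at > 4150 nM, is itself a limit, the step that the limit leaves unreadable from compound 1 to compound 3 is expected to be small and in no clear direction, with weak inhibition remaining the likely outcome. Compound 3 is expected to give about 8000 nM in this assay, within 3000 nM to 30000 nM, most probably again reported as a limit rather than a number.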

Compound 3, half-maximal inhibitory concentration: > 8320 nM
Compound 3: no number, only a limit; the forecaster's own chance of this, stated with the estimate: 75%; middle value at least 1.0-fold (0.01 log units) from the limit.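

In this assay compound 1 and compound 3 both return only limits, so the step between them cannot be read. The compounds shown leave open where any actual value lies, and whether cyclohexyl and 4-methylbenzyl on the amine nitrogen differ at all.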